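A few compounds are considered here, and "the series" means these few. Any claim that something is new, unique, unknown or untested is made for them only; others in the source may bear on it.

Measured compounds:
compound 1 `CC(=O)c1ccc(OCc2ccc(F)cc2)cc1F` — an assay on isolated protein for inhibition of Amine oxidase [flavin-containing] A (Homo sapiens), read by fluorescence, with a stated time of 15 min; a lower number here means a stronger inhibitor, a higher number a weaker inhibitor: > 100000 nM
compound 2 `CC(=O)c1ccc(OCc2cccc(F)c2)cc1F` — this assay: > 100000 nM
compound 3 `CC(=O)c1ccc(OCc2ccc(Cl)cc2)cc1F` — this assay: 89100 nM

The value of compound 1 is a limit of the assay, not a number. The value of compound 2 is likewise a limit. For the measured compounds named here, compound 3 is the only member with a number in this assay. The step of an at least 1.1-fold lower number from compound 1 to compound 3 (0.05 log units; that floor lies within the scatter) rests on (chloro in place of fluoro on an aromatic carbon); because it starts from the limit of > 100000 nM in this assay, at which 2 of the 3 values shown sit, the step can only be given as a floor. How the core of compound 2 differs from the core of compound 1 is not broken down here.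

Compound 4 `CC(=O)c1ccc(OCc2cccc(Cl)c2)cc1F` is not yet measured. It differs from compound 2 by chloro in place of fluoro on an aromatic carbon, the same kind of change as from compound 1 to compound 3, but the place differs: para to a large group in the earlier pair, meta to a large group here. Compound 3 reaches 89100 nM. Compound 2 sits at a limit of the assay. The step to compound 4 is expected to be about a number no higher from compound 2 to compound 4 (the limit leaves the size open). The estimated value for compound 4 is 100000 nM, between 40000 nM and 300000 nM, with a real chance that only a limit is reported.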

Compound 4, half-maximal inhibitory concentration: > 100000 nM
Compound 4: a limit, no number; the forecaster's own chance of this, stated with the estimate: 50%; the middle value sits exactly at the limit.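

In this assay compound 4 gives > 100000 nM, a limit of the assay and not a number. For the compounds shown here, compound 2 also sits at a limit, so no step from compound 2 to compound 4 can be read: the limit of > 100000 nM in this assay, at which 3 of the 4 values shown sit. The compounds shown leave open whether chloro in place of fluoro, meta to a large group, changes inhibition at all.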